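This account rests on a few compounds, and the source may have more. Where it says the series, first, only, none or still open, it means among the compounds named here.

In a functional assay on ACHN cells (Homo sapiens) for inhibition, read by sulforhodamine B assay, with a stated time of 48 h (on this read-out lower numbers stand for stronger inhibition of growth and higher numbers for weaker inhibition of growth), compound 1 (`O=C(Nc1cccc(-n2cc(-c3ccncc3)c(-c3ccc(Cl)c(O)c3)n2)c1)Nc1cccc(C(F)(F)F)c1`) gives > 32500 nM as a limit of the assay and not a number. The true value is therefore unknown, and only one side of it is bounded. Compound 2 (`COc1cc(-c2nn(-c3cccc(NC(=O)Nc4cccc(C(F)(F)F)c4)c3)cc2-c2ccncc2)ccc1Cl`) carries methyl in place of hydrogen on an oxygen on an aromatic ring and reads 3720 nM in this assay as a real number. For the measured compounds named here, that change is the only measured step in this small set: an at least 8.7-fold lower number from compound 1 to compound 2 (0.94 log units; beyond the scatter) shows that the series can come off the limit.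

Compound 3 (`O=C(Nc1cccc(-n2cc(-c3ccncc3)c(-c3ccc(Cl)c(O)c3)n2)c1)Nc1ccc(Cl)c(C(F)(F)F)c1`) changes a different part of compound 1. The change is chloro in place of hydrogen on an aromatic carbon with chloro in place of hydrogen on an aromatic carbon, ortho to a trifluoromethyl group and para to a large group. This turns 3-(trifluoromethyl)phenyl into 4-chloro-3-(trifluoromethyl)phenyl, while the oxygen keeps its hydrogen. Going by the values given here, no measured step covers this change, so an at least 8.7-fold lower number from compound 1 to compound 2 (0.94 log units; beyond the scatter) offers only a loose guide to its size. A modest move toward a lower number is expected, and the result may well stay at the limit. The estimate means an at least 2.0-fold lower number from compound 1 to compound 3 (0.30 log units; that floor lies within the scatter) as an expected step. In this assay the estimate for compound 3 is 16000 nM with an expected range from 4000 nM to 40000 nM on this reading.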

Compound 3, concentration for total growth inhibition: > 32500 nM
Compound 3 ended at the assay's limit; the forecaster's own chance of this, stated with the estimate: 40%; middle value at least 2.0-fold (0.30 log units) away from the limit.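

Compound 1 and compound 3 both stop at the limit of this assay, so the step between them cannot be read: the limit of > 32500 nM in this assay, at which 2 of the 3 values shown sit.

The compounds shown leave open whether 4-chloro-3-(trifluoromethyl)phenyl in place of 3-(trifluoromethyl)phenyl moves the number at all, and if it does, in which direction and by how much.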